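This account rests on a few compounds, and the source may have more. Where it says the series, first, only, none or still open, it means among the compounds named here.

In a functional assay on Caco-2 cells (Homo sapiens) for inhibition, read by sulforhodamine B assay, with a stated time of 48 h (a higher number here means a weaker inhibitor, a lower number a stronger inhibitor), compound 3 `Cc1ccc2occ([C@@H]3C[C@H](OCC(C)C)ON3c3ccccc3)c(=O)c2c1` gives > 60000 nM, which is a limit of the assay and not a number. That is the limit of > 60000 nM in this assay, at which 1 of the 3 values shown sits. Compound 4 `Cc1ccc2occ([C@@H]3C[C@H](c4ccccc4)ON3c3ccccc3)c(=O)c2c1` has phenyl in place of isobutoxy on a saturated ring carbon, and the change is counted as phenyl in place of isobutoxy on a saturated ring carbon.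

Two measured results bear on this change. Compound 2 `CCO[C@H]1C[C@@H](c2coc3ccc(C)cc3c2=O)N(c2ccccc2)O1` carries ethoxy on that ring carbon and gives 31000 nM. The measured step on this chain is an at least 1.9-fold higher number from compound 2 to compound 3 (0.28 log units; that floor lies within the scatter), so varying the chain has not yet shown a change beyond the scatter. Compound 1 `O=c1c([C@@H]2C[C@H](c3ccccc3)ON2c2ccccc2)coc2ccc(F)cc12` is closer to the question, since it already holds phenyl on that ring carbon, although its core differs elsewhere from that of compound 4. Compound 1 gives 60000 nM, so phenyl on a closely related core still gives a weak inhibitor.

On the strength of that value, compound 4 is expected to remain weak, and it may reach the limit of the assay. The expected step is small, with a slightly lower number at most and probably nothing beyond the scatter: an at least 1.2-fold lower number from compound 3 to compound 4 (0.07 log units; that floor lies within the scatter). Compound 4 is estimated at 50000 nM, with an expected range from 20000 nM to 110000 nM.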

Compound 4, half-maximal inhibitory concentration: 31700 nM
The estimate for compound 4 lay 1.6-fold (0.20 log units) above the measured number, within the range that was stated.
By their numbers in this assay, from the lowest: compounds 2, 4 and 1 (each within the scatter of the next).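

In this assay, the value of compound 3 is a limit of the assay and not a number: the limit of > 60000 nM in this assay, at which 1 of the 4 values shown sits. Set against that limit, phenyl in place of isobutoxy on the saturated ring carbon gives an at least 1.8-fold lower number from compound 3 to compound 4 (0.27 log units; that floor lies within the scatter), so this change has a floor but no exact size, and that floor does not clear the scatter. The direct comparisons are firmer: phenyl in place of ethoxy gives a 1.0-fold higher number from compound 2 to compound 4 (0.01 log units; within the scatter), and methyl in place of fluoro on an aromatic carbon, with phenyl kept on the ring, gives a 1.9-fold lower number from compound 1 to compound 4 (0.28 log units; within the scatter), so an aromatic ring and a short ether chain on this carbon cannot be told apart here, and neither can these two small groups on the shared core.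

No step shown so far clears the scatter, so it remains open whether any group on this ring carbon can move the number decisively. An amine, a carboxylic acid or a phenyl ring carrying a methoxy group at this place would test that, as would a larger change on the ring nitrogen's phenyl group.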